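Allyl to isopropyl at the amine-bearing carbon

This account rests on a few compounds, and the source may have more. Where it says the series, first, only, none or still open, it means among the compounds named here.

Compound 1 `CCCCCCCOc1ccc(CCC(N)(CO)CO)cc1` gives 0.049 mg/kg in a functional assay on the whole organism (spleen, spleen) with Rattus norvegicus as the target; on this read-out higher numbers stand for an effect only at larger amounts of compound and lower numbers for an effect already at smaller amounts. Among the compounds with values here, compound 2 `C=CCC(N)(CO)CCc1ccc(OCCCCCCC)cc1` gives 1.9 mg/kg in this assay, the higher of the two numbers measured so far, and the step of a 39-fold higher number from compound 1 to compound 2 (1.59 log units; beyond the scatter) is large. Compound 3 `CCCCCCCOc1ccc(CCC(N)(CO)C(C)C)cc1` is not yet measured in this assay. Its difference from compound 2 is isopropyl in place of allyl on a saturated chain carbon bound to an amine nitrogen and two saturated chain carbons. Within the data shown here, the one measured step concerns a different change, vinyl in place of hydroxy two bonds along the chain from the amine nitrogen, and it is large; no measured step exchanges one hydrocarbon group for another on the carbon bound to the amine nitrogen. Nothing measured bears directly on this exchange, so the expected step is no change at the digits printed from compound 2 to compound 3 (within the scatter), not beyond the scatter. Compound 3 is therefore estimated at 1.9 mg/kg, within a range from 0.6 mg/kg to 6 mg/kg in this assay.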

Compound 3, dose for 50% inhibition: 2.7 mg/kg
Compound 3: middle estimate off by 1.4-fold (0.15 log units), on the low side, within the range that was stated.
By their numbers in this assay, from the lowest: compound 1; then compounds 2 and 3 (each within the scatter of the next).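

In this assay, isopropyl in place of allyl on a saturated chain carbon bound to an amine nitrogen and two saturated chain carbons gives a 1.4-fold higher number from compound 2 to compound 3 (0.15 log units; within the scatter), so the two hydrocarbon groups are not told apart here, with or without the double bond. Isopropyl in place of hydroxymethyl at the same carbon gives a 55-fold higher number from compound 1 to compound 3 (1.74 log units; beyond the scatter) and so joins a 39-fold higher number from compound 1 to compound 2 (1.59 log units; beyond the scatter) as a second large step, which shows that the large step is not peculiar to allyl. No evidence on the cause of these steps is available.

Going by these compounds, it remains open whether aminomethyl or methoxymethyl at this carbon would keep the number near that of compound 1. On these data alone, it is also open whether a methyl group would behave like isopropyl and allyl.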